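Working notes: 6-fluoropyridin-3-yl in place of 4-fluorophenyl

This account rests on a few compounds, and the source may have more. Where it says the series, first, only, none or still open, it means among the compounds named here.

In a functional assay on SW480 cells (Homo sapiens) for antiproliferative activity, read by sulforhodamine B assay, with a stated time of 48 h (on this read-out lower numbers stand for stronger inhibition and higher numbers for weaker inhibition), compound 1 `COc1ccc(C(=O)/C=C/c2ccccc2-c2ccc(F)nc2)cc1` gives 10000 nM as its value and compound 2 `O=C(/C=C/c1ccccc1-c1ccc(F)cc1)c1cccc(O)c1` gives 8700 nM as its value, so the two numbers lie within the scatter of each other and compound 2 stands level with compound 1. Compound 3 `O=C(/C=C/c1ccccc1-c1ccc(F)nc1)c1cccc(O)c1` departs from compound 2 in one place: 6-fluoropyridin-3-yl in place of 4-fluorophenyl on an aromatic carbon ortho to a large group. Among the measured compounds shown here, no measured pair isolates this exchange, since compound 1 and compound 2 differ in more than one place. Compound 1 already carries 6-fluoropyridin-3-yl and still reads 10000 nM in this assay as its value, which gives no hint of a large shift. The expected change a 1.1-fold lower number from compound 2 to compound 3 (0.04 log units; within the scatter) is none beyond the scatter, with no firm direction. Compound 3 is estimated at 8000 nM (expected range 3000 nM to 20000 nM) in this assay for now.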

Compound 3, half-maximal inhibitory concentration: 7400 nM
Compound 3: the middle estimate sits 1.1-fold (0.03 log units) above what was measured; low and high end bracket the measured number.
By their numbers in this assay, from the lowest: compounds 3, 2 and 1 (each within the scatter of the next).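

In this assay the exchange of 4-fluorophenyl for 6-fluoropyridin-3-yl on an aromatic carbon ortho to a large group now has a matched pair, which reads as a 1.2-fold lower number from compound 2 to compound 3 (0.07 log units; within the scatter) and puts the two compounds level. The other pair, 3-hydroxyphenyl in place of 4-methoxyphenyl on a carbonyl carbon, reads as a 1.4-fold lower number from compound 1 to compound 3 (0.13 log units; within the scatter) and is level as well, so neither exchange separates these compounds in this assay. Nothing measured here bears on what lies behind these readings.

Going by these compounds, what an amine or a carboxylic acid in place of the fluorine would do on this ring stays open. Also open, on these data alone, is whether any exchange on the shared core can give a step beyond the scatter, as all three compounds stand level so far.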